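The source may report more compounds than this note shows. Statements on the series, on what has been measured and on what is new or still open speak of the compounds shown alone.

Working notes on the series. The shared core of compound 1 `C=Cc1ccsc1CN[C@@H]1C[C@H]2C[C@@H]([C@H]1C)C2(C)C` is kept throughout, and the group on the amine is what varies. In an ADME assay on MDCK cells (Canis lupus familiaris) for cytotoxicity, read by microscopy, with a stated time of 48 h (on this read-out lower numbers stand for higher toxicity in this test and higher numbers for lower toxicity in this test), compound 1 gives 50000 nM. Compound 3 `C[C@H]1[C@H](NCc2cc(-c3ccccc3)cs2)C[C@H]2C[C@@H]1C2(C)C` in this assay gives 5000 nM, a lower number, with the gap to compound 1 beyond the scatter. Compound 2 `C[C@H]1[C@H](NCc2cnccn2)C[C@H]2C[C@@H]1C2(C)C` in this assay reports only a limit and not a number, > 100000 nM, which is the limit of > 100000 nM in this assay, at which 1 of the 3 values shown sits. Among the two numbers shown, compound 1 thus stands highest; its nearest neighbour is compound 3, whose number is lower by a gap beyond the scatter.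

Compound 4 `CCCc1ccsc1CN[C@@H]1C[C@H]2C[C@@H]([C@H]1C)C2(C)C` differs from compound 1 in one place: propyl in place of vinyl on an aromatic carbon. Among the measured compounds shown here, no pair of measured compounds shows a step of this kind, so the data set no size for it; the change exchanges one small chain for another and touches no ring and no donor or acceptor. The step from compound 1 to compound 4 in this assay is therefore expected to be small, in either direction, and not beyond the scatter, a 1.3-fold lower number from compound 1 to compound 4 (0.10 log units; within the scatter). Compound 4 is estimated to give 40000 nM, with a range from 15000 nM to 100000 nM.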

Compound 4, minimum cytotoxic concentration: 50000 nM
Estimate against measurement, compound 4: 1.3-fold (0.10 log units) below; the range from low to high includes it.
By their numbers in this assay, from the lowest: compound 3; then compounds 1 and 4 (each within the scatter of the next). At a limit, above all of these: compound 2.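

In this assay the exchange of vinyl for propyl on an aromatic carbon of the five-membered aromatic ring with 1 sulfur reads as no change at the digits printed from compound 1 to compound 4 (within the scatter), the first measured size for any step at this position. The double bond outside aromatic rings can therefore leave and the chain can grow from vinyl to propyl with no shift beyond the scatter, so that, for this pair, the read-out does not separate the two small carbon chains. No measurement shown gives a cause for this result.

Vinyl and propyl both carry no hydrogen-bond donors or acceptors and no net charge, so it stays open whether an amine, a carboxylic acid or a much longer chain such as octyl, placed on this same aromatic carbon, would move the minimum cytotoxic concentration beyond the scatter. Compound 2 and compound 3 each differ from compound 1 in more than one place, which leaves open which part of their groups on the amine goes with their values.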